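Estimate for compound 3 from the sulfonamide step

A few compounds are considered here, and "the series" means these few. Any claim that something is new, unique, unknown or untested is made for them only; others in the source may bear on it.

Compound 1 `CCCCc1ccc(CNC(C)=O)c(=O)n1Cc1ccc(-c2ccccc2-c2nn[nH]n2)cc1` gives 3 nM in a functional assay (aorta) for antagonist activity, with Oryctolagus cuniculus as the target (on this read-out lower numbers stand for stronger inhibition and higher numbers for weaker inhibition), and compound 2 `CCCCc1ccc(CNS(C)(=O)=O)c(=O)n1Cc1ccc(-c2ccccc2-c2nn[nH]n2)cc1` gives 2 nM. Compound 2 has the lowest of the two numbers, but the change a 1.5-fold lower number from compound 1 to compound 2 (0.18 log units; within the scatter) lies within the scatter. Compound 3 `CCCCc1ccc(CN(C)S(=O)(=O)c2ccccc2)c(=O)n1Cc1ccc(-c2ccccc2-c2nn[nH]n2)cc1` differs from compound 2 by methyl(phenylsulfonyl)amino in place of methanesulfonamido on a saturated chain carbon bound to an aromatic carbon. Going by the values given here, only that one step touches this part of the molecule, and it was small, so a change in this assay beyond the scatter is not expected in either direction, with broad uncertainty since the added ring has no precedent here. Compound 3 is expected at 5 nM, between 1.5 nM and 20 nM, a step of a 2.5-fold higher number from compound 2 to compound 3 (0.40 log units; beyond the scatter).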

Compound 3, half-maximal inhibitory concentration: 2 nM
The estimate for compound 3 lay 2.5-fold (0.40 log units) above the measured number; low and high end bracket the measured number.
By their numbers in this assay, from the lowest: compounds 2, 3 and 1 (each within the scatter of the next).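

In this assay, methyl(phenylsulfonyl)amino in place of methanesulfonamido (no change at the digits printed from compound 2 to compound 3 (within the scatter)) and in place of acetamido (a 1.5-fold lower number from compound 1 to compound 3 (0.18 log units; within the scatter)) left the number within the scatter. This place, a saturated chain carbon bound to an aromatic carbon, therefore carries a six-membered aromatic ring of carbon only, and a group with no hydrogen-bond donor, with no step beyond the scatter, which the earlier pair did not show. No evidence is available to explain this result. From the compounds shown here alone, whether an amine or a carboxylic acid at this place would give a similar number remains open, as does the effect of a trifluoromethyl group on the new ring.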